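The compounds below may be only part of what the source reports. "The series", "measured", "known", "first", "only" and "open" are said of these compounds alone.

The measured compounds:
compound 1, `CCCCc1ccc(-c2cc(N3CCC(CNS(N)(=O)=O)CC3)ncn2)cc1`: 47200 nM
compound 2, `CCOC(=O)c1ccc(-c2cc(N3CCC(CNS(N)(=O)=O)CC3)ncn2)cc1`: 5000 nM

Within the data shown here, in a functional assay on M21 cells (Homo sapiens) for antiproliferative activity, read by sulforhodamine B assay, with a stated time of 48 h (a higher number here means a weaker inhibitor of growth, a lower number a stronger inhibitor of growth), compound 2 holds the lower of the two numbers; its only neighbour is reached by the step of a 9.4-fold lower number from compound 1 to compound 2 (0.97 log units; beyond the scatter), which lies beyond the scatter. Compound 3, `CCOC(=O)c1ccc(-c2cc(N3CCC(CCNS(N)(=O)=O)CC3)ncn2)cc1`, differs from compound 2 by (sulfamoylamino)methyl in place of sulfamoylamino on a saturated chain carbon bound to a saturated ring carbon. Among the measured compounds shown here, the one measured step concerns a different part of the molecule and gives no guide to this change, so compound 3 is expected to land close to compound 2, with a step of no change at the digits printed from compound 2 to compound 3 (within the scatter) not beyond the scatter. Compound 3 is estimated at 5000 nM, within a range from 2000 nM to 12500 nM.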

Compound 3, concentration for 50% growth inhibition: 9000 nM
Estimate against measurement, compound 3: 1.8-fold (0.26 log units) below, within the range that was stated.
By their numbers in this assay, from the lowest: compounds 2 and 3 (each within the scatter of the next); then compound 1.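

In this assay, the change to the chain on the saturated ring carbon gives a 1.8-fold higher number from compound 2 to compound 3 (0.26 log units; within the scatter), the first step shown at this position. With ethoxycarbonyl kept in place, the extended chain ending in 2-(sulfamoylamino)ethyl therefore stays level with the shorter chain, whereas the earlier step concerned only the aromatic substituent. Nothing available explains this result.

The compounds shown leave open whether a longer chain would also stay level, and whether an amine or a carboxylic acid could take the place of sulfamoylamino at the chain end.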